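Amide nitrogen substituent swap in a cyclohexene carboxamide series

This account rests on a few compounds, and the source may have more. Where it says the series, first, only, none or still open, it means among the compounds named here.

Measured compounds:
compound 1, `COc1ccc(NC(=O)[C@@H]2CC=C(CCC=C(C)C)C[C@H]2c2ccccc2)cc1`: in an assay on isolated protein for inhibition of Apoptosis regulator Bcl-2 (Homo sapiens), read by fluorescence polarization, with stated times of 5 min and 10 min (on this read-out higher numbers stand for weaker inhibition and lower numbers for stronger inhibition), compound 1 gives > 23000 nM, a limit of the assay and not a number.
compound 2, `CC(C)=CCCC1=CC[C@@H](C(=O)NCCC(=O)O)[C@H](c2ccccc2)C1`: in this assay compound 2 gives > 23000 nM, likewise a limit and not a number.

Compound 2 stands at the limit of this assay; no number for it is in hand. For the measured compounds named here, the only measured step, a step that the two limits leave unreadable from compound 1 to compound 2, cannot be read, because both of its end points sit at the limit of > 23000 nM in this assay, at which 2 of the 2 values shown sit. The change to compound 3, `CC(C)=CCCC1=CC[C@@H](C(=O)Nc2ccc(O)cc2)[C@H](c2ccccc2)C1`, is 4-hydroxyphenyl in place of 2-carboxyethyl on an amide-type nitrogen. Going by the values given here, no measured step bears readably on this change: the one step available is hidden by the two limits, and the 4-methoxyphenyl analogue, compound 1, also sits at the limit. There is thus no basis for expecting a step of any size in this assay beyond the scatter, and the expected outcome for the step from compound 2 to compound 3 is a step that the limit leaves unreadable from compound 2 to compound 3, a step that is expected to remain unreadable. Compound 3 is therefore estimated at 30000 nM, with an expected range from 12000 nM to 100000 nM, most likely again reported only as a limit.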

Compound 3, inhibition constant: > 23000 nM
Compound 3 ended at the assay's limit (the forecaster's own chance of this, stated with the estimate: 85%); the middle value lies beyond the limit too.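

No new step can be read in this assay among compound 1, compound 2 and compound 3, because each stands at a limit and not at a number: the limit of > 23000 nM in this assay, at which 3 of the 3 values shown sit. The compounds shown leave open whether these amide nitrogen substituents differ at all in inhibition, and which change would bring a value within the measurable range.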